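The compounds below may be only part of what the source reports. "The series", "measured", "known", "first", "only" and "open" are said of these compounds alone.

Compound 1 `COCCOc1nc(N)nc2c1ncn2/C=C1/CC1(CO)CO` and compound 2 `CN(C)c1nc(N)nc2c1ncn2/C=C1/CC1(CO)CO` share the same core and differ in a single group. In an ADME assay on MOLT-3 cells (Homo sapiens) for cytotoxicity, with a stated time of 7 days (a lower number here means that less compound is tolerated, a higher number that more compound is tolerated), compound 1 gives a result of > 20000 nM, which is a limit of the assay rather than a number. Within the data shown here, for compound 2 the entry in this assay reads "not determined" (no result reported), so it has no number of its own; the only measured value beside it is the limit of > 20000 nM in this assay, at which 1 of the 2 values shown sits. Compound 3 `Nc1nc(NC2CC2)c2ncn(/C=C3/CC3(CO)CO)c2n1` arises from compound 2 by one change, (cyclopropylamino in place of dimethylamino on an aromatic carbon). With compound 2 unmeasured, nothing here shows how that change moves the tolerated concentration. The expectation for compound 3 in this assay is therefore no movement beyond the usual scatter from where compound 1 sits, most likely again a limit. Compound 3 is expected to give about 20000 nM, between 8000 nM and 100000 nM.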

Compound 3, half-maximal cytotoxic concentration: > 20000 nM
Compound 3 gave a limit, no number (the forecaster's own chance of this, stated with the estimate: 70%); the middle value lies on the limit itself.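

In this assay, compound 1 and compound 3 both give a limit rather than a number, so no step can be read between them: the limit of > 20000 nM in this assay, at which 2 of the 3 values shown sit.

The compounds shown leave open how much compound either one tolerates beyond that limit, and whether cyclopropylamino in place of dimethylamino changes the result at all.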